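A few compounds are considered here, and "the series" means these few. Any claim that something is new, unique, unknown or untested is made for them only; others in the source may bear on it.

Of the compounds shown here, three built on one shared core have been measured in an assay on isolated protein for inhibition of Amine oxidase [flavin-containing] A (Homo sapiens), read by fluorescence and spectrophotometry, with a stated time of 20 min; a higher number here means a weaker inhibitor, a lower number a stronger inhibitor. Compound 1, `O=C1/C(=C/c2ccc(F)cc2)Cc2cc(O)ccc21`, gives 679 nM. Compound 2, `Cc1cccc(/C=C2\Cc3cc(O)ccc3C2=O)c1`, gives 860 nM, and compound 3, `O=C1/C(=C/c2ccc(Cl)c(Cl)c2)Cc2cc(O)ccc21`, gives 235 nM. Among these numbers compound 1 stands second highest; its nearest neighbour is compound 2, whose value lies within the scatter of its own, so the two cannot be told apart, while compound 3 lies furthest from it, with a lower number that falls beyond the scatter.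

The next compound, compound 4, `CC(C)c1ccc(/C=C2\Cc3cc(O)ccc3C2=O)cc1`, is not yet measured. It differs from compound 1 in one place: isopropyl in place of fluoro on an aromatic carbon. For the measured compounds named here, no measured pair shows this exact change, so its size can only be judged from the spread of the three values already in hand. A small step is expected, leaning toward a lower number but perhaps no further than the scatter allows: a 1.4-fold lower number from compound 1 to compound 4 (0.13 log units; within the scatter). Compound 4 is therefore expected to give about 500 nM in this assay, most likely somewhere between 200 nM and 1200 nM.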

Compound 4, half-maximal inhibitory concentration: 961 nM
Beside the measured number, compound 4's estimate is 1.9-fold (0.28 log units) below it; low and high end bracket the measured number.
By their numbers in this assay, from the lowest: compound 3; then compounds 1, 2 and 4 (each within the scatter of the next).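

In this assay the step of a 1.4-fold higher number from compound 1 to compound 4 (0.15 log units; within the scatter) comes from putting isopropyl in place of fluoro on this aromatic carbon, so the two compounds cannot be told apart. For the compounds shown here, the position therefore takes a group of 3 heavy atoms in place of one of 1 heavy atom with no change that this assay can resolve, which the earlier compounds, differing from each other in more than one place, could not show. Nothing in hand explains why the number holds steady across this change.

Fluoro and isopropyl both have no hydrogen-bond donors or acceptors and no net charge, so these compounds leave open whether an amine or a carboxylic acid on this carbon would be tolerated as well. They also leave open whether a longer chain there would still stay within the scatter of compound 1.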